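Fluoro in place of chloro: from compound 1 to compound 4

This account rests on a few compounds, and the source may have more. Where it says the series, first, only, none or still open, it means among the compounds named here.

Three measured compounds share one core. Compound 1 `N=C(N)c1ccc(-c2ccc(-c3ccc(Cl)cc3)o2)o1` gives 1810 nM in a functional assay on PC-3 cells (Homo sapiens) for inhibition, read by sulforhodamine B assay, with a stated time of 48 h; a lower number here means a stronger inhibitor of growth, a higher number a weaker inhibitor of growth. Compound 2 `COc1cc(OC)cc(-c2ccc(-c3ccc(C(=N)N)o3)o2)c1` gives 4770 nM in this assay, and compound 3 `N=C(N)c1ccc(-c2ccc(-c3ccc4ccccc4c3)s2)s1` gives 2190 nM in this assay. Compound 1 stands at the low end of these three numbers; the number for compound 3 lies within the scatter of it, whereas the number for compound 2 lies beyond it. Among the measured compounds shown here, no two of the three differ in a single place, so no step between measured compounds can be drawn.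

Compound 4 `N=C(N)c1ccc(-c2ccc(-c3ccc(F)cc3)o2)o1` differs from compound 1 in one place: fluoro in place of chloro on an aromatic carbon. One halogen replaces another at the same place on the ring, and nothing else moves.

For the measured compounds named here, with no comparable step among the measured compounds, the expected step of a 1.4-fold higher number from compound 1 to compound 4 (0.14 log units; within the scatter) in this assay is small, toward a higher number if anything, and may well stay within the scatter. Compound 4 is therefore estimated at 2500 nM, with a range from 1200 nM to 5500 nM.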

Compound 4, concentration for 50% growth inhibition: 1220 nM
Estimate against measurement, compound 4: 2.0-fold (0.31 log units) above; low and high end bracket the measured number.
By their numbers in this assay, from the lowest: compounds 4, 1 and 3 (each within the scatter of the next); then compound 2.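

Among the compounds shown here, the step of a 1.5-fold lower number from compound 1 to compound 4 (0.17 log units; within the scatter) in this assay is the first comparison that changes one place only, and it lies within the scatter. On this aromatic carbon, para to a large group, fluoro and chloro therefore cannot be told apart by this read-out, so this exchange of one halogen for another leaves growth inhibition unchanged as far as the assay can resolve. No other data bear on the interpretation of this step.

On these data alone, whether this place accepts more than a halogen stays open: an amine or a carboxylic acid on the same carbon would test that, and would show whether any change here moves the number beyond the scatter. Also open, as far as these compounds go, is whether the same exchange reads alike on the core of compound 3.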